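A Urea Partner Exchanged: Dichlorophenyl for Trifluoromethylphenyl

The compounds below may be only part of what the source reports. "The series", "measured", "known", "first", "only" and "open" are said of these compounds alone.

Compound 1 `COc1cc(Cl)cc(-c2nn(-c3cccc(NC(=O)c4ccc(Cl)c(Cl)c4)c3)cc2-c2ccncc2)c1` carries a 3,4-dichlorophenyl directly on the carbonyl carbon, and in a functional assay on RXF 393 cells (Homo sapiens) for inhibition, read by sulforhodamine B assay, with a stated time of 48 h, tested at 10 uM (a higher number here means a weaker effect of the compound at the concentration tested, a lower number a stronger effect), compound 1 gives 59.2%. Compound 2 `COc1cc(Cl)cc(-c2nn(-c3cccc(NC(=O)Nc4ccc(Cl)c(Cl)c4)c3)cc2-c2ccncc2)c1` differs by a (3,4-dichlorophenyl)amino in place of 3,4-dichlorophenyl on that carbonyl carbon, and in this assay compound 2 gives 4.46%. Within the data shown here, that single change is the one measured step, a number 54.7 percentage points lower from compound 1 to compound 2 (beyond the scatter), and it leaves compound 2 with the lowest of the two numbers, compound 1 standing beyond the scatter above it.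

Compound 3 `COc1cc(Cl)cc(-c2nn(-c3cccc(NC(=O)Nc4cccc(C(F)(F)F)c4)c3)cc2-c2ccncc2)c1` keeps the linkage of compound 2 but alters the ring on the amide-type nitrogen: 3-(trifluoromethyl)phenyl in place of 3,4-dichlorophenyl on an amide-type nitrogen. Among the measured compounds shown here, no measured step touches this ring exchange; the only step known, from compound 1 to compound 2, concerns the linkage and not the ring, so it gives no guide to size or direction here. Because compound 2 already sits at 4.46%, compound 3 is expected to remain in the strong range, with a modest upward step a number 13.5 percentage points higher from compound 2 to compound 3 (beyond the scatter) allowed for. Compound 3 is estimated at 18%, within a range of 2% to 60%.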

Compound 3, a percentage reported as activity, at one concentration (the size of the read-out at that concentration, not a potency): 11.8%
For compound 3 the middle estimate is 6.2 percentage points above the measured one, within the range that was stated.
By their numbers in this assay, from the lowest: compounds 2 and 3 (each within the scatter of the next); then compound 1.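

On the amide-type nitrogen, 3-(trifluoromethyl)phenyl in place of 3,4-dichlorophenyl gives, in this assay, a number 7.3 percentage points higher from compound 2 to compound 3 (within the scatter), so among the compounds shown this position holds either ring with no difference beyond the scatter. The large effect of the linkage also appears with a second ring: (3-(trifluoromethyl)phenyl)amino in place of 3,4-dichlorophenyl on a carbonyl carbon gives a number 47.4 percentage points lower from compound 1 to compound 3 (beyond the scatter), in the same direction as a number 54.7 percentage points lower from compound 1 to compound 2 (beyond the scatter), so the earlier step is no longer tied to the 3,4-dichlorophenyl ring alone. Nothing given here accounts for either result.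

The compounds shown leave open whether the group on the amide-type nitrogen must be a six-membered aromatic ring of carbon only, since a cyclohexyl group, a pyridine ring or a longer chain is not among them. They also leave open how far that position tolerates other substituents on the ring, such as a carboxylic acid or an amine, and whether the linkage keeps its large step with such partners.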